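Triazolylmethyl in place of phenoxy on the shared core

A few compounds are considered here, and "the series" means these few. Any claim that something is new, unique, unknown or untested is made for them only; others in the source may bear on it.

Of the compounds shown here, three that share one core have been measured in an assay for inhibition of Amine oxidase [flavin-containing] B (Homo sapiens), read by fluorescence and spectrophotometry, using microsomes, with stated times of 30 min and 20 min; a higher number here means a weaker inhibitor, a lower number a stronger inhibitor. Compound 1 `CC(C)(C)c1ccc(-c2noc(-c3ccc(C4=NCCN4)cc3)n2)cc1` carries a tert-butyl group and gives 411 nM. Compound 2 `c1ccc(Oc2ccc(-c3noc(-c4ccc(C5=NCCN5)cc4)n3)cc2)cc1` carries a phenoxy group at the same position and gives 1370 nM. Compound 3 `O=c1c2ccccc2cnn1Cc1noc(-c2ccc(C3=NCCN3)cc2)n1` links the core differently and gives 1260 nM. Among these three numbers compound 2 holds the highest; its gap to compound 3 is within the scatter, while the step of a 3.3-fold higher number from compound 1 to compound 2 (0.52 log units; beyond the scatter) lies beyond it and is the only step that touches the substituent on that ring.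

Compound 4 `c1ncn(Cc2ccc(-c3noc(-c4ccc(C5=NCCN5)cc4)n3)cc2)n1` has not been measured. Relative to compound 2 the change is (1H-1,2,4-triazol-1-yl)methyl in place of phenoxy on an aromatic carbon, on an aromatic carbon of a six-membered aromatic ring of carbon only, para to a large group.

Going by the values given here, only the step from compound 1 to compound 2 bears on this position, and it shows that a change there can move this assay by a modest amount in either direction. Among the compounds with values here, no measured step shows how a triazolylmethyl group behaves here, so no direction beyond the scatter is expected. Compound 4 is therefore estimated at 1500 nM in this assay, with a range from 400 nM to 6000 nM, which means an expected step of a 1.1-fold higher number from compound 2 to compound 4 (0.04 log units; within the scatter).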

Compound 4, half-maximal inhibitory concentration: 9020 nM
Estimate against measurement, compound 4: 6.0-fold (0.78 log units) below; measured number outside the range, above it.
By their numbers in this assay, from the lowest: compound 1; then compounds 3 and 2 (each within the scatter of the next); then compound 4.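

In this assay, going by these compounds alone, this position tolerates much less than the earlier compounds could show: the (1H-1,2,4-triazol-1-yl)methyl group gives a 6.6-fold higher number from compound 2 to compound 4 (0.82 log units; beyond the scatter), and against the tert-butyl group it gives a 22-fold higher number from compound 1 to compound 4 (1.34 log units; beyond the scatter). Within the data shown here, the only earlier step at this position was modest, whereas the three groups now span a large range, and the new group gives the highest number of the three. Phenoxy and (1H-1,2,4-triazol-1-yl)methyl each bring one aromatic ring, so the presence of a ring at this position does not by itself keep the number low, and no measurement is available that explains the rise.

The compounds shown leave open whether the rise follows the nitrogen atoms of the five-membered ring or the methylene link that replaces the oxygen of phenoxy. A benzyl group would keep the link with a ring of carbon only, and an imidazol-1-ylmethyl group would keep the link with one ring nitrogen fewer, so these two groups could begin to separate those features.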